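A few compounds are considered here, and "the series" means these few. Any claim that something is new, unique, unknown or untested is made for them only; others in the source may bear on it.

Compound 1 `O=C(O)c1ccc(/C=C(/SCc2ccc(Cl)cc2)C(=O)c2ccc(C(=O)O)cc2)cc1`: > 100000 nM, a limit
Compound 2 `COc1ccc(/C=C(/SCc2ccc(Cl)cc2)C(=O)c2ccc(C(=O)O)cc2)cc1`: 10000 nM

Going by the values given here, in a functional assay on DU-145 cells (Homo sapiens) for inhibition, read by trypan blue exclusion, with a stated time of 96 h (on this read-out higher numbers stand for weaker inhibition of growth and lower numbers for stronger inhibition of growth), compound 2 gives 10000 nM, the only exact number so far. Compound 3 `O=C(O)c1ccc(C(=O)/C(=C\c2ccc(F)c([N+](=O)[O-])c2)SCc2ccc(Cl)cc2)cc1` changes the aryl group on the double-bonded chain carbon: 4-fluoro-3-nitrophenyl in place of 4-methoxyphenyl on a double-bonded chain carbon bound to a double-bonded chain carbon. Among the compounds with values here, the one measured step, an at least 10-fold lower number from compound 1 to compound 2 (1.00 log units; beyond the scatter), concerns that same group and shows that a change there can exceed the scatter. It does not cover the incoming 4-fluoro-3-nitrophenyl, so no step beyond the scatter is expected, and the expectation stays anchored on compound 2 at 10000 nM. The expected change is a 1.7-fold lower number from compound 2 to compound 3 (0.22 log units; within the scatter). Compound 3 is estimated at 6000 nM, with an expected range from 1000 nM to 40000 nM.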

Compound 3, concentration for 50% growth inhibition: 50000 nM
The estimate for compound 3 lay 8.3-fold (0.92 log units) below the measured number; measured number outside the range, above it.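

At this position, on a double-bonded chain carbon bound to a double-bonded chain carbon, 4-fluoro-3-nitrophenyl in place of 4-methoxyphenyl gives a 5.0-fold higher number from compound 2 to compound 3 (0.70 log units; beyond the scatter) in this assay. Compound 2 therefore stands as the strongest of the three, with its steps to both others beyond the scatter. Against 4-carboxyphenyl, the same group gives an at least 2.0-fold lower number from compound 1 to compound 3 (0.30 log units; that floor lies within the scatter), which is only a floor, since the value of compound 1 is a limit: the limit of > 100000 nM in this assay, at which 1 of the 3 values shown sits.

The compounds shown do not separate the fluoro from the nitro part of 4-fluoro-3-nitrophenyl. Going by these compounds, how an amine or a longer alkoxy chain on this aryl group would read remains open.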